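Naphthyloxyacetyl hydrazone series: removing the aryl methyl

A few compounds are considered here, and "the series" means these few. Any claim that something is new, unique, unknown or untested is made for them only; others in the source may bear on it.

Measured so far in a physicochemical assay for lipophilicity, measured as octanol-water partition; on this read-out higher numbers stand for higher lipophilicity and lower numbers for lower lipophilicity:
- compound 1, `C/C(=N\NC(=O)COc1cccc2ccccc12)c1ccc(C#N)cc1Br`: 3.61
- compound 2, `Cc1ccc(/C=N/NC(=O)COc2cccc3ccccc23)cc1`: 4.49
- compound 3, `COc1ccc(/C=N/NC(=O)COc2cccc3ccccc23)cc1O`: 3.48

Compound 2 stands highest of the three numbers in this assay. Its nearest neighbour is compound 1, whose value lies lower by a margin beyond the usual scatter; the furthest is compound 3, lower still and also beyond the scatter. For the measured compounds named here, no two of the measured compounds differ in a single place, so no measured step is available to anchor the change considered here.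

Compound 4, `O=C(COc1cccc2ccccc12)N/N=C/c1ccccc1`, has not been measured in this assay. Its structure differs from compound 2 in one place: hydrogen in place of methyl on an aromatic carbon. The group that leaves is a methyl and the group that enters is a hydrogen, on an aromatic carbon of a six-membered aromatic ring of carbon only.

For such a change a modest downward step is expected, somewhat larger than the scatter. The step from compound 2 to compound 4 is estimated at a number 0.54 log units lower from compound 2 to compound 4 (beyond the scatter). Compound 4 is accordingly expected to give about 3.95 in this assay, with a likely range from 3.6 to 4.3.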

Compound 4, partition coefficient: 4.02
Compound 4: middle estimate off by 0.07 log units, on the low side, within the range that was stated.
By their numbers in this assay, from the lowest: compounds 3 and 1 (each within the scatter of the next); then compound 4; then compound 2.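

The series now has its first measured single-place step in this assay: hydrogen in place of methyl on an aromatic carbon, para to a large group, gives a number 0.47 log units lower from compound 2 to compound 4 (beyond the scatter). The earlier compounds shown here differ from one another in more than one place, so none of them could isolate this position; here the difference from 4-methylphenyl to phenyl stands alone and the step is modest but beyond the scatter. No accompanying measurement bears on the origin of this step.

This single step does not show how other groups at the same place would read, such as an amine, a carboxylic acid or a longer chain. On these data alone, whether the same change gives a step of similar size when the rest of the core differs also remains open.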